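Removing the allyl group from compound 3

A few compounds are considered here, and "the series" means these few. Any claim that something is new, unique, unknown or untested is made for them only; others in the source may bear on it.

compound 1 `COc1ccc(C(=O)Nc2cc3ccc(OC4CCN(C)CC4)c(C)c3oc2=O)cc1CC=C(C)C`: 1580 nM
compound 2 `C#CCOc1ccc(C(=O)Nc2cc3ccc(OC4CCN(C)CC4)c(C)c3oc2=O)cc1CC=C(C)C`: 1120 nM
compound 3 `C=CCc1cc(C(=O)Nc2cc3ccc(OC4CCN(C)CC4)c(C)c3oc2=O)ccc1OC(C)=O`: 2000 nM

All three compounds were tested in a functional assay on MCF7 cells (Homo sapiens) for antiproliferative activity; on this read-out higher numbers stand for weaker inhibition and lower numbers for stronger inhibition. There, compound 3 gives 2000 nM, which lies within the scatter of the values for both compound 1 and compound 2.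

Compound 4 `CC(=O)Oc1ccc(C(=O)Nc2cc3ccc(OC4CCN(C)CC4)c(C)c3oc2=O)cc1` differs from compound 3 by a single change: hydrogen in place of allyl on an aromatic carbon. The only measured step among these compounds is a 1.4-fold lower number from compound 1 to compound 2 (0.15 log units; within the scatter). It stays within the scatter and concerns a saturated chain carbon bound to an oxygen on an aromatic ring, so it is a different place from the one changed here. Within the data shown here, no measured pair shows what losing the allyl group does, and the step offers only weak guidance. No shift beyond the scatter is therefore expected in this assay, and the data support no firm direction.

The expected step is a 1.3-fold higher number from compound 3 to compound 4 (0.10 log units; within the scatter).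

Compound 4 is estimated at 2500 nM, with an expected range from 800 nM to 7500 nM.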

Compound 4, half-maximal inhibitory concentration: 1620 nM
Compound 4: middle estimate off by 1.5-fold (0.19 log units), on the high side; low and high end bracket the measured number.
By their numbers in this assay, from the lowest: compounds 2, 1, 4 and 3 (each within the scatter of the next).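

Among these compounds, replacing allyl with hydrogen on the aromatic carbon ortho to an acetoxy group gives a 1.2-fold lower number from compound 3 to compound 4 (0.09 log units; within the scatter) in this assay and is the first measured step at this position. The earlier compounds shown here all carried a chain on this carbon, whereas compound 4 shows that the position can hold plain hydrogen with no shift beyond the scatter, so the allyl group makes no measurable difference in this pair. No available evidence bears on why this is so.

The compounds shown leave open whether an amine, a carboxylic acid or a longer chain on this carbon would move the value beyond the scatter. They also leave open whether losing the allyl group would read the same with a methoxy group in place of the acetoxy group.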